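Fluoro in Place of Hydrogen: What Compound 3 May Show

The source may report more compounds than this note shows. Statements on the series, on what has been measured and on what is new or still open speak of the compounds shown alone.

Compound 1 `Cc1ccc(C2CC(c3ccccc3)=NN2C(=O)c2cc3ccccc3o2)cc1` has been measured in a functional assay on A2780 cells (Homo sapiens) for antiproliferative activity, read by MTT assay, with a stated time of 72 h (a higher number here means a weaker inhibitor, a lower number a stronger inhibitor), where compound 1 gives 16.6 ug/mL, the highest of the two numbers recorded so far. Among the measured compounds shown here, its nearest neighbour, compound 2 `O=C(c1cc2ccccc2o1)N1N=C(c2ccccc2)CC1c1ccccc1Cl`, gives 6.22 ug/mL in this assay; the single known step, a 2.7-fold lower number from compound 1 to compound 2 (0.43 log units; beyond the scatter), comes from a 2-chlorophenyl in place of 4-methylphenyl on a saturated ring carbon. Compound 3 `Cc1ccc(C2CC(c3ccc(F)cc3)=NN2C(=O)c2cc3ccccc3o2)cc1` differs from compound 1 in a different place: fluoro in place of hydrogen on an aromatic carbon. For the measured compounds named here, no measured step touches that phenyl, so the known step offers no direct guide, and the data give no basis for expecting movement beyond the scatter. The step of a 1.2-fold lower number from compound 1 to compound 3 (0.07 log units; within the scatter) is therefore expected to be small. Compound 3 is estimated at 14 ug/mL, with a range from 6 ug/mL to 32 ug/mL, in this assay.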

Compound 3, half-maximal inhibitory concentration: > 50 ug/mL
Compound 3 gave a limit, no number (the forecaster's own chance of this, stated with the estimate: 5%); middle value at least 3.5-fold (0.55 log units) away from the limit.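

The change from phenyl to 4-fluorophenyl brings an at least 3.0-fold higher number from compound 1 to compound 3 (0.47 log units; beyond the scatter) in this assay, so a single fluoro on this aromatic carbon, para to a large group, is enough to move the number beyond the scatter, towards a weaker inhibitor. Compound 3 stands at a limit of the assay and not at a number: the limit of > 50 ug/mL in this assay, at which 1 of the 3 values shown sits. The earlier step changed a group on a saturated ring carbon and lowered the number, so the compounds shown now have one change in each direction, at two different places.

Going by these compounds, how far the number rises for compound 3 remains open, and so does the true size of this step. Also open, on these data alone, is whether a chloro, a methoxy or an amine in the place of this fluoro would raise the number too, and whether fluoro would do the same alongside the 2-chlorophenyl group of compound 2.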